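The compounds below may be only part of what the source reports. "The series", "measured", "known", "first", "only" and "open" are said of these compounds alone.

Compound 1 `COc1cc(/C=C2\CN(C)C/C(=C\c3cccnc3)C2=O)cc(OC)c1` gives 6910 nM in a functional assay on HepG2 cells (Homo sapiens) for cytotoxicity, read by MTT assay, with a stated time of 24 h; on this read-out lower numbers stand for stronger inhibition and higher numbers for weaker inhibition.
Compound 2 `CN1C/C(=C\c2ccncc2)C(=O)/C(=C/c2ccccc2F)C1` gives 4600 nM in this assay.
Compound 3 `CN1C/C(=C\c2ccncc2)C(=O)/C(=C/c2ccccc2C(F)(F)F)C1` gives 3300 nM in this assay.

Of these three numbers, compound 3 carries the lowest: compound 2 lies close to it, within the usual scatter, while compound 1 sits further off, beyond it. Compound 4 `N#Cc1ccc(S(=O)(=O)N2C/C(=C\c3ccncc3)C(=O)/C(=C/c3ccccc3C(F)(F)F)C2)cc1` differs from compound 3 in a single place: (4-cyanophenyl)sulfonyl in place of methyl on an amine nitrogen in a ring. For the measured compounds named here, the one measured step, a 1.4-fold lower number from compound 2 to compound 3 (0.14 log units; within the scatter), concerns a swap on an aromatic carbon and not the ring nitrogen, so it does not bear on this change. With no measured guide, no step beyond the scatter is expected, and the range is kept wide to admit either direction. Compound 4 is therefore expected to give 3000 nM in this assay, between 1200 nM and 8000 nM. This corresponds to an expected step of a 1.1-fold lower number from compound 3 to compound 4 (0.04 log units; within the scatter).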

Compound 4, half-maximal inhibitory concentration: 5920 nM
The estimate for compound 4 lay 2.0-fold (0.30 log units) below the measured number; low and high end bracket the measured number.
By their numbers in this assay, from the lowest: compounds 3, 2, 4 and 1 (each within the scatter of the next, the first and the last beyond it).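

Replacing the small methyl on the amine nitrogen in a ring with the much larger (4-cyanophenyl)sulfonyl, which brings in a whole aromatic ring, gives in this assay a 1.8-fold higher number from compound 3 to compound 4 (0.25 log units; within the scatter). So at this position, even a large change in the group leaves the number within the usual scatter. No measurement at hand speaks to the cause of this result.

Going by these compounds, it remains open whether a benzyl group, an acetyl group or a plain hydrogen on this nitrogen would also stay this close to compound 3. Also open, on these data alone, is whether a phenylsulfonyl group, without the nitrile, would behave like compound 4.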